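The source may report more compounds than this note shows. Statements on the series, on what has been measured and on what is new or still open speak of the compounds shown alone.

Measured compounds in an assay on isolated protein for inhibition of Amine oxidase [flavin-containing] A (Rattus norvegicus); a lower number here means a stronger inhibitor, a higher number a weaker inhibitor:

compound 1, `C#CCNCc1cc2ccccc2n1C`: 240 nM
compound 2, `C#CCNCc1cc2cc(O)ccc2n1C`: 4000 nM

Compound 2 holds the highest of the two numbers in this assay; its nearest neighbour is compound 1, with a lower number. Among the measured compounds shown here, the one measured step between them, a 17-fold higher number from compound 1 to compound 2 (1.22 log units; beyond the scatter), is large and beyond the scatter.

Compound 3, `C#CCNCc1cc2cc(OC)ccc2n1C`, differs from compound 2 by methyl in place of hydrogen on an oxygen on an aromatic ring. For the measured compounds named here, no measured pair carries this change, so the only step that bears on it is the one from compound 1 to compound 2, which introduced the hydroxy group itself and raised the number sharply. Compound 3 keeps the oxygen on the aromatic ring but caps it with methyl; whether the number moves back toward that of compound 1 or stays near compound 2 cannot be read from the data. A moderate lowering is taken as the most likely outcome, with wide uncertainty in both directions. Compound 3 is therefore expected to give 1500 nM in this assay, within a range of 400 nM to 6000 nM. The expected step is a 2.7-fold lower number from compound 2 to compound 3 (0.43 log units; beyond the scatter).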

Compound 3, inhibition constant: 0.8 nM
Estimate against measurement, compound 3: 1900-fold (3.27 log units) above; measured number below the stated range.
By their numbers in this assay, from the lowest: compound 3; then compound 1; then compound 2.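

In this assay, methyl on the oxygen on the aromatic ring does more than undo the loss seen with the hydroxy group, giving a 5000-fold lower number from compound 2 to compound 3 (3.70 log units; beyond the scatter). The position itself therefore does not set the direction of the change: the methoxy group gives a 300-fold lower number from compound 1 to compound 3 (2.48 log units; beyond the scatter), whereas the hydroxy group in the same place gave a 17-fold higher number from compound 1 to compound 2 (1.22 log units; beyond the scatter), so among these three compounds the outcome turns on what the oxygen carries. No measured evidence accounts for the size of the methyl step or for the opposite directions of the two steps from compound 1.

The compounds shown leave open whether the gain is particular to methyl on this oxygen or extends to a longer chain, such as ethoxy, or to a ring, such as benzyloxy. They also leave open whether a group without the oxygen on the same aromatic carbon, such as methyl, fluoro or an amine, would follow compound 3 or compound 2, and whether methoxy elsewhere on the shared core would give a similar step.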